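This account rests on a few compounds, and the source may have more. Where it says the series, first, only, none or still open, it means among the compounds named here.

Measured so far in a functional assay on SK-BR-3 cells (Homo sapiens) for antiproliferative activity; a lower number here means a stronger inhibitor, a higher number a weaker inhibitor:
compound 1 `CC(C)=CCc1cc(C(=O)Nc2cc3ccc(OCC4CCCN(C)C4)c(C)c3oc2=O)ccc1O` gives 1300 nM
compound 2 `CC(C)=CCc1cc(C(=O)Nc2cc3ccc(OCCCN4CCCCC4)c(C)c3oc2=O)ccc1O` gives only a limit, > 50000 nM
compound 3 `CC(C)=CCc1cc(C(=O)Nc2cc3ccc(OCCCNC(C)(C)C)c(C)c3oc2=O)ccc1O` gives 660 nM

Compound 3 holds the lowest of the two numbers in this assay. Compound 1 stands nearest to it, and the step of a 2.0-fold lower number from compound 1 to compound 3 (0.29 log units; within the scatter) is within the scatter, so the two cannot be ordered. For compound 2 the assay reports a limit only (the limit of > 50000 nM in this assay, at which 1 of the 3 values shown sits).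

Compound 4 `CC(C)=CCc1cc(C(=O)Nc2cc3ccc(OCCCNC(C)(C)c4ccccc4)c(C)c3oc2=O)ccc1O` differs from compound 3 in one place: phenyl in place of methyl on a saturated chain carbon bound to an amine nitrogen and two saturated chain carbons. Going by the values given here, no measured step changes a substituent on this carbon alone. The two steps that alter the amine end, an at least 75-fold lower number from compound 2 to compound 3 (1.87 log units; beyond the scatter) and an at least 38-fold higher number from compound 1 to compound 2 (1.58 log units; beyond the scatter), were both large, but each exchanges the whole amine, the (tert-butyl)amino against the piperidin-1-yl or the 1-methylpiperidin-3-yl, and neither shows what a phenyl on the carbon next to the amine nitrogen does. The (tert-butyl)amino itself is kept in compound 4. A step in this assay no larger than the scatter, in either direction, is therefore expected, with some allowance for a weaker number given the size of the entering group.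

For compound 4 the estimate in this assay is 900 nM, within 250 nM to 4000 nM, an expected step of a 1.4-fold higher number from compound 3 to compound 4 (0.13 log units; within the scatter).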

Compound 4, half-maximal inhibitory concentration: 960 nM
For compound 4 the middle estimate is 1.1-fold (0.03 log units) below the measured one, within the range that was stated.
By their numbers in this assay, from the lowest: compounds 3, 4 and 1 (each within the scatter of the next). At a limit, above all of these: compound 2.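

On the saturated chain carbon bound to an amine nitrogen and two saturated chain carbons, phenyl in place of methyl is tolerated in this assay, with a 1.5-fold higher number from compound 3 to compound 4 (0.16 log units; within the scatter). The (1-methyl-1-phenylethyl)amino end also cannot be told apart from the 1-methylpiperidin-3-yl side chain, with a 1.4-fold lower number from compound 1 to compound 4 (0.13 log units; within the scatter). The large gap to the piperidin-1-yl side chain persists with this new amine end, with an at least 52-fold lower number from compound 2 to compound 4 (1.71 log units; beyond the scatter), though this step rests on a limit for compound 2: the limit of > 50000 nM in this assay, at which 1 of the 4 values shown sits.

Still open, as far as these compounds go, is what a cyclohexyl, a pyridyl or a fluorophenyl in place of this phenyl would give in this assay. Also open, from the compounds shown here alone, is whether an isopropylamino end or a longer chain between the oxygen and the amine would keep the values of compound 3 and compound 4.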